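The compounds below may be only part of what the source reports. "The series", "measured", "known", "first", "only" and "open" are said of these compounds alone.

Notes on the series in an in vitro ADME assay on microsomes from liver (Homo sapiens) for pharmacokinetics, read by LC-MS, with a stated time of 10 min, tested at 1 uM; on this read-out lower numbers stand for slow clearance and higher numbers for fast clearance. Compound 1 `CN1C[C@H](C(=O)Nc2ccccc2)[C@@H](c2ccc(/C=C/C(=O)Nc3ccccc3N)cc2)C1` gives 7 mL/min/kg and compound 2 `CN1C[C@H](C(=O)Nc2ccc(C(F)(F)F)cc2)[C@@H](c2ccc(/C=C/C(=O)Nc3ccccc3N)cc2)C1` gives 6 mL/min/kg. Compound 3 `CN1C[C@H](C(=O)Nc2ccc(F)c(Cl)c2)[C@@H](c2ccc(/C=C/C(=O)Nc3ccccc3N)cc2)C1` stands highest of the three at 15 mL/min/kg. Compound 4 `Cc1cc(NC(=O)[C@H]2CN(C)C[C@@H]2c2ccc(/C=C/C(=O)Nc3ccccc3N)cc2)ccc1F` departs from compound 3 by methyl in place of chloro on an aromatic carbon, ortho to a fluoro group. Among the measured compounds shown here, no measured step makes this exact exchange. The nearest evidence is the whole-group exchanges, a 2.1-fold higher number from compound 1 to compound 3 (0.33 log units; beyond the scatter) and a 2.5-fold higher number from compound 2 to compound 3 (0.40 log units; beyond the scatter), both modest, while a 1.2-fold lower number from compound 1 to compound 2 (0.07 log units; within the scatter) shows a larger substituent change staying within the scatter. A single-atom exchange is therefore expected to give no step beyond the scatter, and the expected step is a 1.2-fold lower number from compound 3 to compound 4 (0.06 log units; within the scatter). Compound 4 is estimated at 13 mL/min/kg, with an expected range of 7 mL/min/kg to 24 mL/min/kg.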

Compound 4, clearance: 15 mL/min/kg
Compound 4: the middle estimate sits 1.2-fold (0.06 log units) below what was measured, within the range that was stated.
By their numbers in this assay, from the lowest: compounds 2 and 1 (each within the scatter of the next); then compounds 3 and 4 (each within the scatter of the next).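

In this assay, among the compounds shown here, methyl in place of chloro on an aromatic carbon, ortho to a fluoro group, is the first single-atom exchange read at this position, and it stays within the scatter (no change at the digits printed from compound 3 to compound 4 (within the scatter)). The 4-fluoro-3-methylphenyl group stands as far from the lower pair as the 3-chloro-4-fluorophenyl group does (a 2.1-fold higher number from compound 1 to compound 4 (0.33 log units; beyond the scatter); a 2.5-fold higher number from compound 2 to compound 4 (0.40 log units; beyond the scatter)). No measurement on hand accounts for this.

Open, on these data alone, is whether a methoxy group, an amine or a carboxylic acid at this carbon would also stay within the scatter of compound 3 and compound 4.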